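Working notes: ring swap on the aromatic nitrogen, compound 4

This account rests on a few compounds, and the source may have more. Where it says the series, first, only, none or still open, it means among the compounds named here.

Measured so far in a functional assay on HCC827 cells (Homo sapiens) for antiproliferative activity, read by MTT assay, with a stated time of 72 h; a lower number here means a stronger inhibitor, a higher number a weaker inhibitor:
compound 1 `CN1CCN(c2ccc(Nc3ncc4nc(SCc5ccccc5)n(C5CCOCC5)c4n3)cc2)CC1` gives 107 nM
compound 2 `CN1CCN(c2ccc(Nc3ncc4nc([S+]([O-])c5ccccc5)n([C@H]5CC[C@H](O)CC5)c4n3)cc2)CC1` gives 268 nM
compound 3 `CN1CCN(c2ccc(Nc3ncc4nc(Sc5ccccc5)n([C@H]5CC[C@H](O)CC5)c4n3)cc2)CC1` gives 42.6 nM

Compound 2 stands highest of the three numbers in this assay. Among the measured compounds shown here, its one defined step is a 6.3-fold lower number from compound 2 to compound 3 (0.80 log units; beyond the scatter), a modest change at the sulfur-bearing group. Compound 1 is nearer, with compound 1 at 107 nM set against compound 2 at 268 nM; this pair differs at two places at once, so it is not resolved as a single step.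

Compound 4 `CN1CCN(c2ccc(Nc3ncc4nc([S+]([O-])c5ccccc5)n(C5CCCC5)c4n3)cc2)CC1` keeps the sulfur-bearing group of compound 2 and changes only the ring on the nitrogen: cyclopentyl in place of 4-hydroxycyclohexyl on an aromatic nitrogen

For the measured compounds named here, none of the measured steps bears on this change. Going by the values given here, the only quantified step, a 6.3-fold lower number from compound 2 to compound 3 (0.80 log units; beyond the scatter), concerns the group on the aromatic carbon, which compound 4 leaves untouched. Compound 1 carries a different ring on the same aromatic nitrogen, but its other change prevents any reading of that ring alone. The loss of the hydroxyl donor and acceptor is therefore unbacked by a matched pair. The expectation is a step of a 1.3-fold higher number from compound 2 to compound 4 (0.12 log units; within the scatter), within or near the scatter, direction uncertain. Compound 4 is estimated at 350 nM, with a range of 120 nM to 1000 nM.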

Compound 4, half-maximal inhibitory concentration: 64.7 nM
Beside the measured number, compound 4's estimate is 5.4-fold (0.73 log units) above it, and the stated range ends above it.
By their numbers in this assay, from the lowest: compounds 3, 4 and 1 (each within the scatter of the next, the first and the last beyond it); then compound 2.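

With the sulfur-bearing group held fixed, the ring on the aromatic nitrogen now has its first matched step in this assay, a 4.1-fold lower number from compound 2 to compound 4 (0.62 log units; beyond the scatter), so this position moves the number, as does the group on the aromatic carbon, whose only step is a 6.3-fold lower number from compound 2 to compound 3 (0.80 log units; beyond the scatter). For this pair, the hydroxyl of the 4-hydroxycyclohexyl is not needed to reach the lower number, since cyclopentyl, which has 0 hydrogen-bond donors and 0 hydrogen-bond acceptors, gives it. Nothing measured here explains the step, and the change alters ring size, heavy-atom count and the hydroxyl together, so no single one of these can be credited with it.

The compounds shown leave open whether the step follows the hydroxyl or the ring, a question that a plain cyclohexyl on the same nitrogen would separate, while a 4-aminocyclohexyl would test another group at the same ring position. They also leave open whether cyclopentyl gives a similar step when paired with the group that compound 3 carries on the aromatic carbon.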